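A few compounds are considered here, and "the series" means these few. Any claim that something is new, unique, unknown or untested is made for them only; others in the source may bear on it.

Working notes on the series. In a functional assay on HT cells (Homo sapiens) for antiproliferative activity, read by fluorescence, with a stated time of 72 h (on this read-out higher numbers stand for weaker inhibition of growth and lower numbers for stronger inhibition of growth), compound 1 (`CSc1nc(NCc2ccc(-c3ccccn3)cc2)c2[nH]nc(C(C)C)c2n1`) gives 783 nM and compound 2 (`CC(C)c1n[nH]c2c(NCc3ccc(-c4ccccn4)cc3)nc(SC[C@H](O)CN)nc12`) gives 63 nM as the lower of the two numbers, a gap beyond the scatter. Compound 3 (`COCSc1nc(NCc2ccc(-c3ccccn3)cc2)c2[nH]nc(C(C)C)c2n1`) is the next to be read. It carries methoxy in place of 2-amino-1-hydroxyethyl on a saturated chain carbon bound to a sulfur, the same difference as 3-amino-2-hydroxypropyl to methoxymethyl.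

Among the compounds with values here, one measured step bears on this change. The large step of a 12-fold lower number from compound 1 to compound 2 (1.09 log units; beyond the scatter) came with 2-amino-1-hydroxyethyl in place of hydrogen at that same place. Compound 3 no longer has that group, so a move back towards compound 1 is expected in this assay as a higher number, of moderate to large size and beyond the scatter. Within the data shown here, no measured compound shows how methoxy compares with hydrogen at this place, so the range is kept wide. The expected change is a 7.1-fold higher number from compound 2 to compound 3 (0.85 log units; beyond the scatter) on this estimate. For compound 3 the estimated value is 450 nM with an expected range from 170 nM to 1100 nM as the working figure.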

Compound 3, concentration for 50% growth inhibition: 340 nM
For compound 3 the middle estimate is 1.3-fold (0.12 log units) above the measured one; low and high end bracket the measured number.
By their numbers in this assay, from the lowest: compound 2; then compound 3; then compound 1.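

Methoxy in place of hydrogen on a saturated chain carbon bound to a sulfur is itself enough to shift the read-out in this assay, with a 2.3-fold lower number from compound 1 to compound 3 (0.36 log units; beyond the scatter), so this place responds to a group that has no hydrogen-bond donors and no 2-amino-1-hydroxyethyl part. The amino alcohol chain still matters in the same assay: methoxy in place of 2-amino-1-hydroxyethyl gives a 5.4-fold higher number from compound 2 to compound 3 (0.73 log units; beyond the scatter), so part of the gain from the larger group remains with methoxy and part is lost, and the order at this place in these three compounds runs from 2-amino-1-hydroxyethyl through methoxy to hydrogen. Nothing available explains this order or ties it to any property of the groups.

The compounds shown do not separate the amine from the hydroxyl within 3-amino-2-hydroxypropyl, so a chain ending in a primary amine alone or in a hydroxyl alone could still account for most or little of the lower number of compound 2. On these data alone, it also remains open whether a plain ethyl group or a longer carbon chain at this place would read like methoxy, and whether the opposite stereocentre of the amino alcohol would read like compound 2.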